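Dropping a Methyl Group on the Fluorophenyl Ring

The source may hold more compounds than are shown below. What is called first, only, known or untested is meant among the compounds shown, and "the series" means these compounds.

Going by the values given here, compound 2 `COc1ccc(-n2cnc3cnc(-c4ccc(F)cc4C)cc32)cc1OC` is the one compound here with a measured number: in a functional assay on HL-60 cells (Homo sapiens) for activation, read by flow cytometry, with a stated time of 4 days (on this read-out lower numbers stand for an effect already at smaller amounts and higher numbers for an effect only at larger amounts of compound), compound 2 gives 15 nM. Compound 1 `COc1ccc(-n2cnc3cnc(Oc4cccc(NC(C)=O)c4)cc32)cc1OC`, which carries a different group on the shared core, reaches only (the limit of > 30000 nM in this assay, at which 1 of the 2 values shown sits). That value is a limit of the assay and not a number, so in this assay compound 1 gives > 30000 nM as a limit. Compound 3 `COc1ccc(-n2cnc3cnc(-c4ccc(F)cc4)cc32)cc1OC` differs from compound 2 in one place: hydrogen in place of methyl on an aromatic carbon. No pair of measured compounds differing in a single place is available, so the size of this step cannot be read from the data, and no cause for it can be given. A small weakening, near the edge of the usual scatter, is expected for the step of a 2.7-fold higher number from compound 2 to compound 3 (0.43 log units; beyond the scatter). Compound 3 is expected to give 40 nM in this assay, with a range from 10 nM to 160 nM.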

Compound 3, half-maximal effective concentration: 780 nM
The estimate for compound 3 lay 20-fold (1.29 log units) below the measured number, and the stated range ends below it.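

Taking the methyl group away, so that 4-fluoro-2-methylphenyl becomes 4-fluorophenyl, gives a 52-fold higher number from compound 2 to compound 3 (1.72 log units; beyond the scatter) in this assay and is a large step. It shows that this aromatic carbon, ortho to a large group, is a sensitive place in compound 2: a change of just 1 carbon is enough to move the number far beyond the usual scatter. Nothing measured among these compounds says why a single methyl group matters so much here.

With only methyl and hydrogen shown at this place, it remains open whether an ethyl group, a chlorine atom or a methoxy group would keep the low number of compound 2 or lose it as hydrogen does. Going by these compounds, it also remains open whether the same step would be as large on a different core.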